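A Methoxy Swap on the Shared Core

The source may report more compounds than this note shows. Statements on the series, on what has been measured and on what is new or still open speak of the compounds shown alone.

Compound 1 `COc1ccc(OC)c(C2=C(c3cc(OC)c(OC)c(OC)c3)C(=O)CC2O[SiH2]C(C)(C)C)c1` gives 17 ug/mL
Compound 2 `COc1ccc(C2=C(c3cc(OC)c(OC)c(OC)c3)C(=O)C(O)C2)cc1Cl` gives > 100 ug/mL as a limit of the assay
Compound 3 `COc1ccc(C2=C(c3cc(OC)c(OC)c(OC)c3)C(=O)C(O[SiH2]C(C)(C)C)C2)cc1` gives 7 ug/mL

In an ADME assay on PA-1 cells (Homo sapiens) for cytotoxicity, read by MTT assay, with a stated time of 72 h (a higher number here means a weaker inhibitor, a lower number a stronger inhibitor), compound 1 at 17 ug/mL holds the higher of the two exact numbers. Compound 3 at 7 ug/mL sits lower, by more than the usual scatter. The entry for compound 2 at > 100 ug/mL is a limit of the assay and not a number.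

Compound 4 `COc1ccc(C2=C(c3cc(OC)c(OC)c(OC)c3)C(=O)CC2O[SiH2]C(C)(C)C)cc1OC` has the same atoms as compound 1, joined differently, and 3,4-dimethoxyphenyl in place of 2,5-dimethoxyphenyl on a double-bonded ring carbon sums up the change: 3,4-dimethoxyphenyl in place of 2,5-dimethoxyphenyl on a double-bonded ring carbon. Going by the values given here, no two measured compounds differ in one place only, so no measured step guides this swap. In this assay no step beyond the scatter is expected, with a 1.2-fold lower number from compound 1 to compound 4 (0.08 log units; within the scatter) as the estimate of its size. Compound 4 is expected at 14 ug/mL with a likely range from 5 ug/mL to 40 ug/mL once measured.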

Compound 4, half-maximal inhibitory concentration: > 100 ug/mL
Compound 4 was reported as a limit (the forecaster's own chance of this, stated with the estimate: 7%); middle value at least 7.1-fold (0.85 log units) away from the limit.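

In this assay, 3,4-dimethoxyphenyl in place of 2,5-dimethoxyphenyl on a double-bonded ring carbon gives an at least 5.8-fold higher number from compound 1 to compound 4 (0.76 log units; beyond the scatter). Going by these compounds alone, this is the first comparison here between two compounds that differ in one place, and it shows that this position is sensitive to where the two methoxy groups sit on the phenyl ring, even though the atoms and the counted features of the group stay the same. The entry for compound 4 is a limit of the assay and not a number, so the full size of the step stays unknown: the limit of > 100 ug/mL in this assay, at which 2 of the 4 values shown sit.

The compounds shown do not tell whether one methoxy group alone accounts for the step. They also leave open how a phenyl ring carrying an amine or a carboxylic acid would behave at this ring carbon.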